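Swapping chloro for bromo on the aryl urea end

This account rests on a few compounds, and the source may have more. Where it says the series, first, only, none or still open, it means among the compounds named here.

Measured compounds:
compound 1, `COc1cc(NC(C)CCCNC(=O)Nc2ccc(Br)cc2)c2ncccc2c1`: 23000 nM
compound 2, `COc1cc(NC(C)CCCNC(=O)NNC(=O)Nc2ccc(Cl)cc2)c2ncccc2c1`: 108000 nM

In a functional assay on CCRF-CEM cells (Homo sapiens) for inhibition, read by MTT assay, with a stated time of 72 h (on this read-out lower numbers stand for stronger inhibition and higher numbers for weaker inhibition), compound 2 gives the highest of the two numbers shown; its nearest neighbour is compound 1, reached by a 4.7-fold higher number from compound 1 to compound 2 (0.67 log units; beyond the scatter). Compound 3 is `COc1cc(NC(C)CCCNC(=O)NNC(=O)Nc2ccc(Br)cc2)c2ncccc2c1` and differs from compound 2 by bromo in place of chloro on an aromatic carbon. Among the compounds with values here, no measured step changes chloro to bromo on an aromatic carbon, so the single step that is known does not bear directly on this change. Compound 3 is therefore expected to sit close to compound 2, with a 1.1-fold lower number from compound 2 to compound 3 (0.03 log units; within the scatter) not beyond the scatter; the estimate for compound 3 is 100000 nM, within 40000 nM to 250000 nM.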

Compound 3, half-maximal inhibitory concentration: 110000 nM
For compound 3 the middle estimate is 1.1-fold (0.04 log units) below the measured one; low and high end bracket the measured number.
By their numbers in this assay, from the lowest: compound 1; then compounds 2 and 3 (each within the scatter of the next).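

In this assay, bromo can replace chloro on this aromatic carbon without a change beyond the scatter, a 1.0-fold higher number from compound 2 to compound 3 (0.01 log units; within the scatter). With bromo now on both sides of the comparison, the longer carbamoyl-amino linkage still gives a weaker result, a 4.8-fold higher number from compound 1 to compound 3 (0.68 log units; beyond the scatter), so the earlier gap does not rest on the chloro-bromo difference. Nothing available explains either result. On these data alone, whether fluoro, methoxy or a plain hydrogen on this carbon would also leave the number unchanged stays open. So does the effect of an amine on the phenyl ring.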